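This account rests on a few compounds, and the source may have more. Where it says the series, first, only, none or still open, it means among the compounds named here.

Working notes on the series. Among the measured compounds shown here, in an ADME assay on the whole organism (serum) for protein binding, with Rattus norvegicus as the target, using equilibrium dialysis, compound 2 (`O=C(O)c1cn(Cc2ccc(-c3ccccc3)cc2)c2ccsc2c1=O`) gives 99.2%, the lowest unbound fraction of the two compounds measured so far. Compound 1 (`O=C(O)c1cn(Cc2ccc(-n3cccn3)cc2)c2ncccc2c1=O`) gives 95.2%, an unbound fraction beyond the scatter from that of compound 2. For the measured compounds named here, no measured pair differs in one place only, so no direct step is available as a guide.

Compound 3 (`O=C(O)c1cn(Cc2ccc(-n3ccnc3)cc2)c2ccsc2c1=O`) has 1H-imidazol-1-yl in place of phenyl on an aromatic carbon, para to a large group: 1H-imidazol-1-yl in place of phenyl on an aromatic carbon. In this assay, a shift towards more free compound is expected, of a size beyond the scatter. Going by the values given here, the only support is compound 1 at 95.2%, which shows that a member of this series can bind less. The expected change is a 4.4-fold higher unbound fraction from compound 2 to compound 3 (0.64 log units; beyond the scatter). For compound 3 the estimated value is 96.5%, with an expected range of 92% to 98.8%.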

Compound 3, plasma protein binding: 74.1%
Estimate against measurement, compound 3: 7.4-fold (0.87 log units) (unbound fraction) below; the whole stated range lies above it.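

Among the compounds shown here, with 1H-imidazol-1-yl in place of phenyl on an aromatic carbon, para to a large group, this assay shows a 32-fold higher unbound fraction from compound 2 to compound 3 (1.51 log units; beyond the scatter), the first direct reading of a single change. This position is therefore not silent: with the core of compound 2 kept, one exchange of ring at this place moves the read-out well beyond the scatter. Nothing at hand bears on the reason for a step of this size.

For the compounds shown here, open is whether a pyridin-3-yl ring or morpholin-4-yl at this place would give a step of similar size, and whether 1H-pyrazol-1-yl, seen only in compound 1, would do so on the core of compound 2. Also open, from the compounds shown here alone, is whether the same exchange would carry over to the core of compound 1.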